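The source may hold more compounds than are shown below. What is called first, only, known or untested is meant among the compounds shown, and "the series" means these compounds.

Measured so far:
- compound 1, `Nc1ccccc1-c1cnc(C(=O)CCCCCCc2ccccc2)o1`, with 750 nM in an assay (Rattus norvegicus) for inhibition of Fatty-acid amide hydrolase 1 (Homo sapiens); on this read-out higher numbers stand for weaker inhibition and lower numbers for stronger inhibition
- compound 2, `NC(=O)c1cccc(-c2cnc(C(=O)CCCCCCc3ccccc3)o2)n1`, with 1 nM
- compound 3, `O=C(CCCCCCc1ccccc1)c1ncc(-c2cncnc2)o1`, with 22 nM

All three share one core and differ only in the group attached to an aromatic carbon of the five-membered ring. Compound 3 stands second highest of the three numbers in this assay: the step of a 22-fold higher number from compound 2 to compound 3 (1.34 log units; beyond the scatter), and the step of a 34-fold lower number from compound 1 to compound 3 (1.53 log units; beyond the scatter), so the group at this carbon moves the number a great deal in both directions.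

Compound 4 is `O=C(CCCCCCc1ccccc1)c1ncc(I)o1`. It differs from compound 3 by iodo in place of pyrimidin-5-yl on an aromatic carbon, placed on an aromatic carbon of a five-membered aromatic ring with 1 nitrogen and 1 oxygen, next to the ring oxygen. Within the data shown here, no measured step removes the aromatic group entirely, so the two large steps above show only that this position is sensitive. A sizeable rise in number is expected in this assay; compound 4 is estimated at 600 nM, with a range from 80 nM to 5000 nM, which means an expected step of a 27-fold higher number from compound 3 to compound 4 (1.44 log units; beyond the scatter).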

Compound 4, inhibition constant: 3 nM
For compound 4 the middle estimate is 200-fold (2.30 log units) above the measured one, and the stated range ends above it.
By their numbers in this assay, from the lowest: compound 2; then compound 4; then compound 3; then compound 1.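

In this assay, an aromatic ring at this carbon turns out not to be required for a low number: iodo, which has no ring, gives a 7.3-fold lower number from compound 3 to compound 4 (0.87 log units; beyond the scatter) and a 250-fold lower number from compound 1 to compound 4 (2.40 log units; beyond the scatter). Yet a ring is not simply worse than iodo, since iodo still gives a 3.0-fold higher number from compound 2 to compound 4 (0.48 log units; beyond the scatter), which leaves compound 2 below compound 4 while compound 3 and compound 1 lie above it. No measurement in hand explains this order.

The compounds shown leave open whether chloro, bromo or a plain hydrogen at this carbon would behave like iodo. They also leave open whether a small group such as a nitrile or a carboxylic acid could match the 6-carbamoylpyridin-2-yl group of compound 2 without its ring.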